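The source may hold more compounds than are shown below. What is called first, only, known or untested is meant among the compounds shown, and "the series" means these compounds.

Compound 1 `Cc1ccccc1-c1nn(-c2ccccc2Cl)cc1CNCCN1CCN(C)CC1` was tested in an ADME assay on Huh-7 cells (Homo sapiens) for cytotoxicity; on this read-out higher numbers stand for lower toxicity in this test and lower numbers for higher toxicity in this test. In this assay compound 1 gives > 20000 nM, which is a limit of the assay and not a measured number. Compound 2 `Cc1ccccc1-c1nn(-c2ccc(F)cc2F)cc1CNCCCCO` likewise reaches only a limit, > 20000 nM, in this assay. Both values sit at the limit of > 20000 nM in this assay, at which 2 of the 2 values shown sit. Compound 3 `Cc1ccccc1-c1nn(Cc2ccccc2)cc1CNCCN1CCN(C)CC1` differs from compound 1 by benzyl in place of 2-chlorophenyl on an aromatic nitrogen. Among the measured compounds shown here, no step between measured compounds is available here, and how this change bears on cytotoxicity cannot be read from the two limits alone. A step that the limit leaves unreadable from compound 1 to compound 3 is expected, meaning no change beyond the scatter. Compound 3 is estimated at 25000 nM, between 10000 nM and 60000 nM.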

Compound 3, half-maximal cytotoxic concentration: > 20000 nM
Compound 3 ended at the assay's limit (the forecaster's own chance of this, stated with the estimate: 80%); the middle value does not contradict the limit.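

In this assay compound 3 gives > 20000 nM, again a limit of the assay, so no step can be read between compound 1 and compound 3: the limit of > 20000 nM in this assay, at which 3 of the 3 values shown sit. As far as these compounds go, whether benzyl in place of 2-chlorophenyl changes the result at all stays open, as does the true value of each of the three compounds.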